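This account rests on a few compounds, and the source may have more. Where it says the series, first, only, none or still open, it means among the compounds named here.

Measured so far in an assay on isolated protein for inhibition of DNA topoisomerase 1 (Homo sapiens), with a stated time of 30 min, tested at 100 uM; on this read-out higher numbers stand for a stronger effect at the one concentration tested and lower numbers for a weaker effect:

Compound 1, `COc1ccc(-c2cc3ccccc3c(-c3cccc(N)c3)n2)cc1`: 0%
Compound 2, `COc1ccc(-c2cc3ccccc3c(-c3ccc(O)cc3)n2)cc1`: 6.7%

Compound 2 stands highest of the two numbers, but only by a margin within the scatter: a number 6.7 percentage points higher from compound 1 to compound 2 (within the scatter), for a 4-hydroxyphenyl in place of a 3-aminophenyl on an aromatic carbon. Neither compound shows inhibition beyond the scatter at the single concentration tested.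

Compound 3, `COc1ccc(-c2cc3ccccc3c(-c3ccc(OC)cc3)n2)cc1`, is not yet measured in this assay. It differs from compound 2 by methyl in place of hydrogen on an oxygen on an aromatic ring.

For the measured compounds named here, no measured step bears directly on this change; the only measured step exchanges one aryl group for another and is itself within the scatter. Going by the values given here, both compounds measured so far sit near the floor of the read-out, and a methyl in place of hydrogen on an oxygen on an aromatic ring gives no reason on these numbers to expect a departure from that. The expected step is a number 2.7 percentage points lower from compound 2 to compound 3 (within the scatter), which is within the scatter. Compound 3 is estimated at 4%, with a range from 0% to 15%.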

Compound 3, a percentage reported as inhibition, at one concentration (the size of the read-out at that concentration, not a potency): 0%
Compound 3: the middle estimate sits 4 percentage points above what was measured; measured number inside the range.
By their numbers in this assay, from the lowest: compounds 1, 3 and 2 (each within the scatter of the next).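

Methyl in place of hydrogen on an oxygen on an aromatic ring now has a measured step in this assay: a number 6.7 percentage points lower from compound 2 to compound 3 (within the scatter). At the single concentration tested, the free hydroxy and the methoxy on this aromatic ring therefore cannot be told apart, and the exchange of aryl groups, no change at the digits printed from compound 1 to compound 3 (within the scatter), gives the same picture, with the 3-aminophenyl, 4-hydroxyphenyl and 4-methoxyphenyl compounds showing no separation from one another. Nothing available offers an account of why these three read-outs lie so close together.

The compounds shown leave open whether a longer chain on this oxygen, or a carboxylic acid or an amine in place of the whole methoxy group, would give a read-out clearly separated from these three. The rest of the shared core is the same in compound 1, compound 2 and compound 3, so the effect of any change elsewhere on the core cannot be read from this set.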